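Trimming the Amine Side Chain in an L6 Cytotoxicity Series

The source may hold more compounds than are shown below. What is called first, only, known or untested is meant among the compounds shown, and "the series" means these compounds.

Measured in an ADME assay on L6 cells (Rattus norvegicus) for cytotoxicity; a lower number here means a stronger inhibitor, a higher number a weaker inhibitor:
- compound 1 `COc1cc2c(cc1C(C)OCCc1ccccc1)C=CC(C)(C)O2`: 123000 nM
- compound 2 `COc1cc2c(cc1C(C)NC(=O)/C=C/c1ccccc1)C=CC(C)(C)O2`: 107000 nM
- compound 3 `COc1ccc(CNC(C)c2cc3c(cc2OC)OC(C)(C)C=C3)cc1`: 14900 nM

Of these three compounds, compound 3 has the lowest number in this assay, at 14900 nM. Compound 1 and compound 2 both lie well beyond the scatter on the higher side of it, and the two of them stand close together.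

The next compound is compound 4 `CCNC(C)c1cc2c(cc1OC)OC(C)(C)C=C2`, which keeps the amine nitrogen of compound 3 but shortens the chain on it. The change is methyl in place of 4-methoxyphenyl on a saturated chain carbon bound to an amine nitrogen.

Within the data shown here, no measured pair differs in only one place, so the data give no direct size for this change. Among the measured compounds shown here, compound 3, at 14900 nM, is the only measured compound with this amine, and losing its aromatic ring leaves the outcome open. A moderate rise beyond the scatter is expected, towards a weaker inhibitor, though probably not all the way to the values of the other two. The expected change is a 3.0-fold higher number from compound 3 to compound 4 (0.48 log units; beyond the scatter). The estimate for compound 4 is 45000 nM, with an expected range from 15000 nM to 130000 nM.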

Compound 4, half-maximal inhibitory concentration: 176000 nM
Beside the measured number, compound 4's estimate is 3.9-fold (0.59 log units) below it; the measured number lies above the stated range.
By their numbers in this assay, from the lowest: compound 3; then compounds 2, 1 and 4 (each within the scatter of the next).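

Replacing 4-methoxyphenyl with methyl on a saturated chain carbon bound to an amine nitrogen gives a 12-fold higher number from compound 3 to compound 4 (1.07 log units; beyond the scatter) in this assay, the first direct measure of a change at this position. The amine nitrogen is present in both compounds, so it is not enough on its own to give the low number of compound 3; that number is lost when the 4-methoxyphenyl group leaves, and the compound becomes a much weaker inhibitor. Nothing measured here explains why the step is so large.

This single step removes the aromatic ring, its methoxy group and most of the group's heavy atoms together, so the compounds shown leave open which of these features matters for the number in this assay. A plain phenyl, a 4-methylphenyl, a cyclohexyl ring or a longer chain such as propyl at the same place would help to separate those features, and would show whether the number returns towards that of compound 3 only when an aromatic ring is present.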